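Notes on the amine substituent: compound 3 to compound 4

The source may report more compounds than this note shows. Statements on the series, on what has been measured and on what is new or still open speak of the compounds shown alone.

Compound 3 `c1cc(CNC2CCN(CCCc3c[nH]c4ccc(-n5cnnc5)cc34)CC2)co1` gives 4.5 nM in an assay on CHO cells for displacement of a labelled ligand from 5-hydroxytryptamine receptor 1D (Homo sapiens) (on this read-out lower numbers stand for stronger inhibition and higher numbers for weaker inhibition), the second highest of the three numbers measured; compound 1 `c1ccc2c(c1)CCC2NC1CCN(CCCc2c[nH]c3ccc(-n4cnnc4)cc23)CC1` gives 8.9 nM and compound 2 `CN(C1CCN(CCCc2c[nH]c3ccc(-n4cnnc4)cc23)CC1)S(=O)(=O)c1ccccc1` gives 1.5 nM. Compound 4 `CN(Cc1ccsc1)C1CCN(CCCc2c[nH]c3ccc(-n4cnnc4)cc23)CC1` is not yet measured; it differs from compound 3 by methyl((thiophen-3-yl)methyl)amino in place of ((furan-3-yl)methyl)amino on a saturated ring carbon. Going by the values given here, no measured step covers this exact change. The nearest are a 5.9-fold lower number from compound 1 to compound 2 (0.77 log units; beyond the scatter), where a methyl and a phenylsulfonyl arrived together, and a 3.0-fold higher number from compound 2 to compound 3 (0.48 log units; beyond the scatter); a 2.0-fold lower number from compound 1 to compound 3 (0.30 log units; within the scatter) shows how little a change of the aromatic ring alone moved the number. Compound 4 is therefore expected to show a small step toward a lower number, if any beyond the scatter, a 1.5-fold lower number from compound 3 to compound 4 (0.18 log units; within the scatter). The estimate for compound 4 is 3 nM, with a range from 1 nM to 9 nM.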

Compound 4, half-maximal inhibitory concentration: 1.5 nM
For compound 4 the middle estimate is 2.0-fold (0.30 log units) above the measured one; the range from low to high includes it.
By their numbers in this assay, from the lowest: compounds 2 and 4 (each within the scatter of the next); then compounds 3 and 1 (each within the scatter of the next).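

In this assay the amine on the saturated ring carbon proves sensitive to its substituents, with a 3.0-fold lower number from compound 3 to compound 4 (0.48 log units; beyond the scatter) when methyl((thiophen-3-yl)methyl)amino enters in place of ((furan-3-yl)methyl)amino. Phenylsulfonyl is not needed for the lowest numbers here: (thiophen-3-yl)methyl in its place gives no change at the digits printed from compound 2 to compound 4 (within the scatter) and replacing (2,3-dihydro-1H-inden-1-yl)amino gives a 5.9-fold lower number from compound 1 to compound 4 (0.77 log units; beyond the scatter) as well. Nothing available explains these steps.

From the compounds shown here alone, the separate shares of the added methyl and of thiophene in place of furan remain open. Also open, going by these compounds, is how a benzyl group or a longer chain on that amine nitrogen would read.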